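This account rests on a few compounds, and the source may have more. Where it says the series, first, only, none or still open, it means among the compounds named here.

Measured so far:
- compound 1 `CC(C)N(Cc1cccc(OCCCCCC(=O)O)c1)C(=O)c1ccccc1`: in an ADME assay on HEK293 cells (Homo sapiens) for cytotoxicity, read by CellTiter-Glo and resazurin assay, with a stated time of 72 h (a higher number here means that more compound is needed for the effect, a lower number that less compound is needed), compound 1 gives > 26000 nM, which is a limit of the assay.
- compound 2 `CC(C)N(Cc1cccc(OCCCCCC(=O)O)c1)C(=O)c1ccc(-c2c[nH]c3ccccc23)cc1`: compound 2 gives > 26000 nM, again a limit.
- compound 3 `CCOC(=O)CCCCCOc1cccc(CN(C(=O)c2ccccc2)C(C)C)c1`: compound 3 gives > 26000 nM, also a limit.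

Compound 3 therefore stands at a limit only, and so do the two other values shown; all three sit at the limit of > 26000 nM in this assay, at which 3 of the 3 values shown sit. The two measured steps, a step that the two limits leave unreadable from compound 1 to compound 2 and a step that the two limits leave unreadable from compound 1 to compound 3, are for that reason of unreadable size, and neither tells in which direction, if any, cytotoxicity moves on adding a ring to the aromatic carbon or an ethyl to the acid oxygen.

The next compound, compound 4 `CCOC(=O)CCCCCOc1cccc(CN(C(=O)c2ccc(-c3cnc(OC)nc3OC)cc2)C(C)C)c1`, differs from compound 3 by 2,4-dimethoxypyrimidin-5-yl in place of hydrogen on an aromatic carbon. Among the measured compounds shown here, this change resembles the one from compound 1 to compound 2 in kind, an aromatic ring entering on the same aromatic carbon, and that pair gave no readable step. With nothing in the series pointing to a cytotoxic effect within range, compound 4 is expected to show no step beyond the scatter, a number no higher from compound 3 to compound 4 (the limit leaves the size open). The value of compound 4 in this assay is estimated at 26000 nM, between 13000 nM and 52000 nM, most likely reported again as a limit.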

Compound 4, half-maximal effective concentration: > 26000 nM
Compound 4: only a limit was reported; the forecaster's own chance of this, stated with the estimate: 80%; the middle value sits exactly at the limit.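

In this assay compound 4 gives > 26000 nM as a limit of the assay. Among the compounds shown here, no step from compound 3 to compound 4 can be read, as the series stands at one value only: the limit of > 26000 nM in this assay, at which 4 of the 4 values shown sit. The compounds shown leave open whether any change to the shared core brings cytotoxicity within the measurable range, and in which direction.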